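The source may report more compounds than this note shows. Statements on the series, on what has been measured and on what is new or still open speak of the compounds shown alone.

In an ADME assay on BJ cells (Homo sapiens) for cytotoxicity, read by MTT assay, with a stated time of 72 h (a lower number here means a stronger inhibitor, a higher number a weaker inhibitor), compound 2 `COc1ccc(CNc2ncnc3c2ncn3C2CCCCO2)cc1` gives > 100000 nM, which is a limit of the assay and not a number. Compound 1 `Oc1ccccc1CNc1ncnc2c1ncn2C1CCCCO1` gives > 100000 nM, also a limit. Compound 2 therefore stands with all the measured data at one point: the limit of > 100000 nM in this assay, at which 2 of the 2 values shown sit. Compound 3 `Oc1cccc(CNc2ncnc3c2ncn3C2CCCCO2)c1O` differs from compound 2 by 2,3-dihydroxyphenyl in place of 4-methoxyphenyl on a saturated chain carbon bound to a nitrogen on an aromatic ring. Going by the values given here, only one measured step bears on this change, and no sizeable shift can be expected in this assay because a step that the two limits leave unreadable from compound 1 to compound 2 gives no readable size. The expected result is a number no higher from compound 2 to compound 3 (the limit leaves the size open), with no direction beyond the scatter. For compound 3 the estimate is 100000 nM, within an expected range of 40000 nM to 200000 nM.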

Compound 3, half-maximal inhibitory concentration: 63300 nM
For compound 3 the middle estimate is 1.6-fold (0.20 log units) above the measured one; the measured number falls inside the stated range.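

In this assay compound 3, with 2,3-dihydroxyphenyl on a saturated chain carbon bound to a nitrogen on an aromatic ring, is the only compound shown that gives a number and not a limit. The change from 4-methoxyphenyl gives an at least 1.5-fold lower number from compound 2 to compound 3 (0.19 log units; that floor lies within the scatter), and hydroxy in place of hydrogen on an aromatic carbon gives an at least 1.5-fold lower number from compound 1 to compound 3 (0.19 log units; that floor lies within the scatter). Both steps are floors, with a limit at one end: the limit of > 100000 nM in this assay, at which 2 of the 3 values shown sit.

The compounds shown leave open how large either step truly is. From the compounds shown here alone, whether an amine or a carboxylic acid in place of the hydroxy groups would shift the number also remains open.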